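From 3-methylbenzyl to 2,5-dimethylbenzyl: cytotoxicity notes

This account rests on a few compounds, and the source may have more. Where it says the series, first, only, none or still open, it means among the compounds named here.

Values in an ADME assay on MT4 cells (Homo sapiens) for cytotoxicity, read by MTT assay, with a stated time of 4 days; a lower number here means that less compound is tolerated, a higher number that more compound is tolerated:
Compound 1 `Cc1ccc(OCCn2ccc(=O)n(Cc3ccccc3)c2=O)cc1`: 187000 nM
Compound 2 `Cc1ccc(OCCn2ccc(=O)n(Cc3cccc(C)c3)c2=O)cc1`: >= 38000 nM, a limit

Compound 2 has no number in this assay, only the limit >= 38000 nM. Its standing against compound 1 cannot be read.

Compound 3 `Cc1ccc(OCCn2ccc(=O)n(Cc3cc(C)ccc3C)c2=O)cc1` differs from compound 2 by methyl in place of hydrogen on an aromatic carbon, which takes 3-methylbenzyl to 2,5-dimethylbenzyl. Among the compounds with values here, the one measured step of the same kind, a step that the limit leaves unreadable from compound 1 to compound 2, also puts methyl in place of hydrogen on an aromatic carbon, but it gives neither size nor direction. The series holds (the limit of >= 38000 nM in this assay, at which 1 of the 2 values shown sits). Within the data shown here, no direction is expected for the new step, and the only firm number to lean on is compound 1 at 187000 nM. Compound 3 may well return only a limit too.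

The expected change is a step that the limit leaves unreadable from compound 2 to compound 3, read against a limit and so only loosely sized. For compound 3 the estimated value is 100000 nM, with an expected range from 30000 nM to 250000 nM.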

Compound 3, half-maximal cytotoxic concentration: > 343000 nM
Compound 3 gave a limit, no number; the forecaster's own chance of this, stated with the estimate: 55%; middle value at least 3.4-fold (0.53 log units) from the limit.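

In this assay compound 3 gives only a limit, > 343000 nM. Adding a second methyl to the benzyl ring gives the first readable step at this position, an at least 1.8-fold higher number from compound 1 to compound 3 (0.26 log units; that floor lies within the scatter); this sets a floor, but it does not establish a real rise in the tolerated concentration. The steps into and out of compound 2 cannot be read, so the separate contribution of the methyl in 3-methylbenzyl and of the added methyl in 2,5-dimethylbenzyl stays unresolved.

Only compound 1 has a firm number, which leaves the true size of the shift with methyl substitution on this ring open. Also open, as far as these compounds go, is whether the tolerated concentration stays this high with an amine or a carboxylic acid on the benzyl ring in place of methyl.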